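The source may report more compounds than this note shows. Statements on the series, on what has been measured and on what is new or still open speak of the compounds shown alone.

Values in a functional assay on HT29-AK cells (Homo sapiens) for cytotoxicity, read by MTT assay, with a stated time of 48 h; on this read-out higher numbers stand for weaker inhibition and lower numbers for stronger inhibition. Compound 1 `Fc1cccc(-c2nc(Nc3ccccc3)c3cc(F)ccc3n2)c1` gives 48300 nM. Compound 2 `COc1ccccc1Nc1nc(-c2cccc(F)c2)nc2ccc(F)cc12` gives a limit, > 50000 nM. Compound 3 `Fc1cccc(-c2nc(Nc3ccccc3Cl)c3cc(F)ccc3n2)c1` gives a limit, > 50000 nM.

Compound 3 thus stands at the limit (the limit of > 50000 nM in this assay, at which 2 of the 3 values shown sit), and its value is not a number. The change to compound 4 `Oc1cccc(Nc2nc(-c3cccc(F)c3)nc3ccc(F)cc23)c1` is 3-hydroxyphenyl in place of 2-chlorophenyl on a nitrogen on an aromatic ring. Among the measured compounds shown here, two measured steps touch this ring: an at least 1.0-fold higher number from compound 1 to compound 3 (0.01 log units; that floor lies within the scatter) and an at least 1.0-fold higher number from compound 1 to compound 2 (0.01 log units; that floor lies within the scatter). Between them, a step that the two limits leave unreadable from compound 2 to compound 3. For the measured compounds named here, no measured step covers a hydroxyl on this ring, and none gives a readable size. The expected step is therefore none beyond the scatter, with a fair chance that only a limit is again reported. Compound 4 is estimated at 50000 nM, expected to lie between 15000 nM and 200000 nM. This means an expected step of a number no higher from compound 3 to compound 4 (the limit leaves the size open).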

Compound 4, half-maximal inhibitory concentration: > 50000 nM
Compound 4: no number, only a limit; the forecaster's own chance of this, stated with the estimate: 60%; the middle value lies on the limit itself.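

Hydroxy in place of hydrogen on this ring gives an at least 1.0-fold higher number from compound 1 to compound 4 (0.01 log units; that floor lies within the scatter). Compound 4 has only a limit in this assay, so the 3-hydroxyphenyl group, the first here with a hydrogen-bond donor, shows no readable gain, and the steps among compound 2, compound 3 and compound 4 cannot be read. Substituents on this ring now cluster at one ceiling: the limit of > 50000 nM in this assay, at which 3 of the 4 values shown sit.

Going by these compounds, whether an amine or a carboxylic acid on this ring would give a value under the limit stays open. With compound 1 alone giving a number, no substituent effect can yet be sized.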